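Swapping the halogenated aryl on the ring nitrogen

The source may hold more compounds than are shown below. What is called first, only, known or untested is meant among the compounds shown, and "the series" means these compounds.

Measured compounds:
- compound 1, `CNC(=O)c1cc(Oc2ccc(NC(=O)c3cc4cccnc4n(-c4ccc(Br)cc4)c3=O)cc2)ccn1`: 1180 nM
- compound 2, `CCNC(=O)c1cc(Oc2ccc(NC(=O)c3cc4cccnc4n(-c4ccccc4)c3=O)cc2)ccn1`: 220 nM
- compound 3, `CCNC(=O)c1cc(Oc2ccc(NC(=O)c3cc4cccnc4n(-c4ccc(Br)cc4)c3=O)cc2)ccn1`: 1160 nM

All three share one core and are tested in a functional assay on HT-29 cells (Homo sapiens) for antiproliferative activity, read by MTT assay, with a stated time of 72 h; on this read-out lower numbers stand for stronger inhibition and higher numbers for weaker inhibition. Compound 3 gives the second highest of the three numbers; its step from compound 1 is a 1.0-fold lower number from compound 1 to compound 3 (0.01 log units; within the scatter), while compound 2 stands apart, the step being a 5.3-fold higher number from compound 2 to compound 3 (0.72 log units; beyond the scatter).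

Compound 4, `CCNC(=O)c1cc(Oc2ccc(NC(=O)c3cc4cccnc4n(-c4ccc(F)c(Cl)c4)c3=O)cc2)ccn1`, has not been measured. It differs from compound 3 in one place: 3-chloro-4-fluorophenyl in place of 4-bromophenyl on an aromatic nitrogen. Among the measured compounds shown here, the only measured step that touches this position is the one from compound 2 to compound 3, where a bromo replaced a hydrogen and the number rose modestly. For the measured compounds named here, no measured step shows what a 3-chloro-4-fluorophenyl does here, so the direction is open. The new group is again a halogenated aryl, and the expected step of a 1.7-fold lower number from compound 3 to compound 4 (0.22 log units; within the scatter) is small and uncertain. Compound 4 is therefore estimated at 700 nM in this assay, with a range from 250 nM to 2000 nM.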

Compound 4, half-maximal inhibitory concentration: 2600 nM
The estimate for compound 4 lay 3.7-fold (0.57 log units) below the measured number; the whole stated range lies below it.
By their numbers in this assay, from the lowest: compound 2; then compounds 3 and 1 (each within the scatter of the next); then compound 4.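

In this assay, this position on the aromatic nitrogen responds to which halogenated aryl sits there, not merely to whether a halogen is present: replacing 4-bromophenyl with 3-chloro-4-fluorophenyl gives a 2.2-fold higher number from compound 3 to compound 4 (0.35 log units; beyond the scatter). Measured against the unsubstituted phenyl, the same group gives a 12-fold higher number from compound 2 to compound 4 (1.07 log units; beyond the scatter), so both halogenated aryls shown carry higher numbers than phenyl, and this one moves further. No measurement available here bears on what lies behind these steps.

Chlorine and fluorine enter together, so the compounds shown cannot separate the contribution of each halogen. From the compounds shown here alone, it also remains open whether a phenyl bearing an amine or a methoxy group, or a saturated ring such as cyclohexyl, would give a lower number than the phenyl of compound 2.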